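The source may report more compounds than this note shows. Statements on the series, on what has been measured and on what is new or still open speak of the compounds shown alone.

Measured in a functional assay on WM 266-4 cells (Homo sapiens) for antiproliferative activity, read by MTT assay, with a stated time of 24 h; a higher number here means a weaker inhibitor of growth, a lower number a stronger inhibitor of growth:
- compound 1 `COc1ccc(C2CC(c3ccc4c(c3)OCCO4)=NN2c2ccccc2)cc1OC`: 2160 nM
- compound 2 `c1ccc(COc2cccc(C3CC(c4ccc5c(c4)OCCO5)=NN3c3ccccc3)c2)cc1`: 870 nM
- compound 3 `Fc1ccc(C2CC(c3ccc4c(c3)OCCO4)=NN2c2ccccc2)cc1`: 6050 nM

Among these three, compound 1 has the second highest number, above compound 2 and below compound 3. Compound 4 `Clc1ccc(C2CC(c3ccc4c(c3)OCCO4)=NN2c2ccccc2)cc1` is not yet measured. It carries 4-chlorophenyl in place of 3,4-dimethoxyphenyl on a saturated ring carbon. Among the compounds with values here, one measured step bears on this change, the swap to 4-fluorophenyl at the same place, which gave a 2.8-fold higher number from compound 1 to compound 3 (0.45 log units; beyond the scatter). A step of similar size and the same direction is therefore expected in this assay. The estimated step is a 2.2-fold higher number from compound 1 to compound 4 (0.35 log units; beyond the scatter). Compound 4 is estimated at 4800 nM, with an expected range from 1900 nM to 12000 nM.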

Compound 4, concentration for 50% growth inhibition: 38600 nM
Beside the measured number, compound 4's estimate is 8.0-fold (0.91 log units) below it; the measured number lies above the stated range.
By their numbers in this assay, from the lowest: compound 2; then compound 1; then compound 3; then compound 4.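

In this assay, the saturated ring carbon responds far more strongly to 4-chlorophenyl than the fluoro swap had indicated, with an 18-fold higher number from compound 1 to compound 4 (1.25 log units; beyond the scatter) on this change. The two halogens are not interchangeable here: chloro in place of fluoro on an aromatic carbon gives a 6.4-fold higher number from compound 3 to compound 4 (0.80 log units; beyond the scatter) and so the result depends on which halogen enters, not only on the loss of 3,4-dimethoxyphenyl. Nothing measured here accounts for this difference. From the compounds shown here alone, whether a 4-bromophenyl or a 4-methoxyphenyl group on this carbon would fall nearer compound 3 or compound 4 stays open, as does the effect of an amine on that phenyl ring.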